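Trifluoromethyl in Place of Nitro: What Compound 3 May Show

The source may hold more compounds than are shown below. What is called first, only, known or untested is meant among the compounds shown, and "the series" means these compounds.

Of the compounds shown here, two built on one shared core have been measured. Compound 1 `CC(=O)c1ccc(OCc2ccc(C)cc2)cc1` carries a methyl group on its outer ring, and in an assay on isolated protein for inhibition of Amine oxidase [flavin-containing] B (Homo sapiens), read by Amplex Red, with a stated time of 15 min (a lower number here means a stronger inhibitor, a higher number a weaker inhibitor), compound 1 gives 102 nM. Compound 2 `CC(=O)c1ccc(OCc2ccccc2[N+](=O)[O-])cc1` carries a nitro group instead, and in this assay compound 2 gives 284 nM, the higher of the two numbers. The gap between compound 2 and compound 1 is beyond the usual scatter.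

Compound 3 `CC(=O)c1ccc(OCc2ccccc2C(F)(F)F)cc1` has not yet been measured. It differs from compound 2 in one place: trifluoromethyl in place of nitro on an aromatic carbon. Among the measured compounds shown here, no measured pair shows this exchange, so nothing fixes its size. The step from compound 2 to compound 3 in this assay is expected to be small, at most a modest move downward, a 1.4-fold lower number from compound 2 to compound 3 (0.15 log units; within the scatter). Compound 3 is therefore estimated at 200 nM, with a range from 60 nM to 700 nM.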

Compound 3, half-maximal inhibitory concentration: 183 nM
Beside the measured number, compound 3's estimate is 1.1-fold (0.04 log units) above it; measured number inside the range.
By their numbers in this assay, from the lowest: compounds 1, 3 and 2 (each within the scatter of the next, the first and the last beyond it).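

In this assay the exchange of nitro for trifluoromethyl on an aromatic carbon, ortho to a large group, gives a 1.6-fold lower number from compound 2 to compound 3 (0.19 log units; within the scatter) and so leaves the two groups indistinguishable at this place. The result also shows that the 2 hydrogen-bond acceptors of nitro can give way to the 0 hydrogen-bond acceptors of trifluoromethyl without a change beyond the scatter. Nothing available bears on the reason for this result.

From the compounds shown here alone, whether an amine, a carboxylic acid or a methoxy group at the same place would keep the number within the scatter of compound 2 remains open. Also open, going by these compounds, is how trifluoromethyl would fare on another carbon of that ring, or how the two groups would compare on a core with a different chain.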